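The source may hold more compounds than are shown below. What is called first, only, known or untested is meant among the compounds shown, and "the series" means these compounds.

Measured compounds:
compound 1 `O=C(O)Cn1c(SCc2ccccc2Cl)nc2ccccc21` — 370 nM
compound 2 `Cc1ccccc1CSc1nc2ccccc2n1CC(=O)O` — 810 nM

In an assay on HEK293 cells for displacement of a labelled ligand from prostaglandin D2 receptor 2 (Homo sapiens) (on this read-out higher numbers stand for weaker inhibition and lower numbers for stronger inhibition), compound 1 gives 370 nM, and compound 2 gives 810 nM. Among the compounds with values here, compound 2 therefore holds the higher of the two numbers so far; the only step between them is a 2.2-fold higher number from compound 1 to compound 2 (0.34 log units; beyond the scatter), which places compound 2 beyond the scatter from compound 1 in the direction of weaker inhibition.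

The next compound, compound 3 `COC(=O)c1ccccc1CSc1nc2ccccc2n1CC(=O)O`, has not yet been measured. It differs from compound 2 in one place: methoxycarbonyl in place of methyl on an aromatic carbon. Within the data shown here, no measured step involves a methoxycarbonyl group, so the single step from compound 1 to compound 2 is the only one that bears on this site at all. It shows that a change at this position can move the number by a modest amount, but it does not say which way an ester will move it. With so little to go on, compound 3 is expected to land near compound 2, with a modest step of a 1.5-fold higher number from compound 2 to compound 3 (0.17 log units; within the scatter) toward a higher number and a wide band of uncertainty. The estimate for compound 3 in this assay is 1200 nM, between 300 nM and 5000 nM.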

Compound 3, half-maximal inhibitory concentration: 520 nM
Beside the measured number, compound 3's estimate is 2.3-fold (0.36 log units) above it; the range from low to high includes it.
By their numbers in this assay, from the lowest: compounds 1, 3 and 2 (each within the scatter of the next, the first and the last beyond it).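

In this assay, methoxycarbonyl, with 4 heavy atoms and 2 hydrogen-bond acceptors, takes the place of methyl, with 1 heavy atom and 0 hydrogen-bond acceptors, and the outcome is a 1.6-fold lower number from compound 2 to compound 3 (0.19 log units; within the scatter); on this aromatic carbon, then, a change of this size in atom count and acceptors need not move the number beyond the scatter. Set against chloro, the same ester gives a 1.4-fold higher number from compound 1 to compound 3 (0.15 log units; within the scatter), so it cannot be told apart from either of the earlier groups, even though those two are separated by a 2.2-fold higher number from compound 1 to compound 2 (0.34 log units; beyond the scatter) and the three compounds therefore do not fall into a clear order at this position. Nothing measured here accounts for these numbers.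

The compounds shown leave open whether an amine, a carboxylic acid or a longer ester chain on this aromatic carbon would stay within the same narrow span or move the number beyond the scatter. They also leave open whether the hydrogen-bond acceptors of the methoxycarbonyl group matter at all, since a single ester cannot separate their part from that of its added atoms.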